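Nitrobenzylidene cyclohexanones: dimethylamino enters the second arene

The source may hold more compounds than are shown below. What is called first, only, known or untested is meant among the compounds shown, and "the series" means these compounds.

Three compounds of the shared core have numbers in a functional assay on MOLT-4 cells (Homo sapiens) for cytotoxicity, with a stated time of 72 h; on this read-out higher numbers stand for weaker inhibition and lower numbers for stronger inhibition. Compound 1 `O=C1/C(=C/c2ccccc2)CCC/C1=C\c1cccc([N+](=O)[O-])c1` gives 1700 nM, the lowest of the three. Compound 3 `O=C1/C(=C/c2ccc(F)cc2)CCC/C1=C\c1ccccc1[N+](=O)[O-]` gives 1870 nM, which lies within the scatter of compound 1. Compound 2 `Cc1ccc(/C=C2\CCC/C(=C\c3ccccc3[N+](=O)[O-])C2=O)cc1` gives 7520 nM, a higher number than compound 1 by more than the scatter. Among the measured compounds shown here, the single one-place step, a 4.0-fold lower number from compound 2 to compound 3 (0.60 log units; beyond the scatter), is the only measured information on what a group on the second arene does in this assay.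

Compound 4 `CN(C)c1ccc(/C=C2\CCC/C(=C\c3cccc([N+](=O)[O-])c3)C2=O)cc1` is the next compound: dimethylamino in place of hydrogen on an aromatic carbon. For the measured compounds named here, no measured step exchanges hydrogen for dimethylamino, and compound 1 and compound 4 carry the nitro group on the same arene as each other, unlike compound 2 and compound 3. The step from compound 2 to compound 3 shows that exchanging one group for another on the second arene moves this assay by a modest amount, so a step of comparable size is plausible here, in either direction. The step of a 1.5-fold higher number from compound 1 to compound 4 (0.17 log units; within the scatter) is expected to be modest, with its direction uncertain. Compound 4 is estimated at 2500 nM, in the range 800 nM to 8000 nM.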

Compound 4, half-maximal inhibitory concentration: 10900 nM
Beside the measured number, compound 4's estimate is 4.4-fold (0.64 log units) below it, outside the stated range (above it).
By their numbers in this assay, from the lowest: compounds 1 and 3 (each within the scatter of the next); then compounds 2 and 4 (each within the scatter of the next).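

Dimethylamino in place of hydrogen on an aromatic carbon, para to a large group, gives a 6.4-fold higher number from compound 1 to compound 4 (0.81 log units; beyond the scatter) in this assay and so moves the number towards weaker inhibition. The earlier step of a 4.0-fold lower number from compound 2 to compound 3 (0.60 log units; beyond the scatter) only exchanged one group for another, whereas this one starts from hydrogen and shows that a group entering this arene on the core of compound 1 can cost more than the scatter. No measurement at hand accounts for this step.

From the compounds shown here alone, it remains open whether the higher number belongs to dimethylamino itself or would follow any group at this place on the core of compound 1. A methoxy group, a primary amine or the longer diethylamino group at the same place would begin to separate these readings.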